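This account rests on a few compounds, and the source may have more. Where it says the series, first, only, none or still open, it means among the compounds named here.

- compound 1 `O=C(NCc1ccc(Cl)cc1Cl)[C@@H]1CCC(=O)N1c1cccs1` gives 0.025 h
- compound 2 `O=C(NCc1ccc(Cl)cc1Cl)[C@@H]1CCC(=O)N1c1ccoc1` gives 0.0483 h

In an ADME assay on microsomes from liver (Homo sapiens) for metabolic stability, read by HPLC, with a stated time of 60 min, tested at 0.2 mg/mL (a lower number here means that the compound disappears faster, a higher number that the compound lasts longer), compound 2 gives 0.0483 h and stands within the scatter of compound 1. Compound 3 `O=C(NCc1ccc(Cl)cc1Cl)[C@@H]1CCC(=O)N1c1cscn1` carries 1,3-thiazol-4-yl in place of furan-3-yl on an amide-type nitrogen in a ring on an amide-type nitrogen in a ring. Among the compounds with values here, the only measured step bearing on this change is a 1.9-fold higher number from compound 1 to compound 2 (0.29 log units; within the scatter) and it also exchanges one five-membered aromatic ring for another at that place. No step beyond the scatter is therefore expected in this assay and the data give no direction. The estimated step is a 1.2-fold higher number from compound 2 to compound 3 (0.09 log units; within the scatter) and it remains a working expectation. For compound 3 the estimated half-life is 0.06 h with an expected range from 0.02 h to 0.17 h for now.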

Compound 3, half-life: 0.08 h
Estimate against measurement, compound 3: 1.3-fold (0.12 log units) below; the range from low to high includes it.
By their numbers in this assay, from the lowest: compounds 1, 2 and 3 (each within the scatter of the next, the first and the last beyond it).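

In this assay, within the data shown here, the thiophen-2-yl to 1,3-thiazol-4-yl exchange gives a 3.2-fold higher number from compound 1 to compound 3 (0.51 log units; beyond the scatter) and is the first change on this amide-type nitrogen to pass the scatter, so the choice of five-membered aromatic ring at this place can shift the half-life, if only modestly. The other new step, a 1.7-fold higher number from compound 2 to compound 3 (0.22 log units; within the scatter), leaves 1,3-thiazol-4-yl and furan-3-yl indistinguishable. Nothing at hand bears on what lies behind these steps.

Open, as far as these compounds go, is whether a phenyl or pyridin-3-yl group on this nitrogen would hold or extend the half-life. Also open, from the compounds shown here alone, is how a methyl group on the 1,3-thiazol-4-yl ring would act.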